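Adding dimethylamino to the acetyl chain of compound 3

A few compounds are considered here, and "the series" means these few. Any claim that something is new, unique, unknown or untested is made for them only; others in the source may bear on it.

In a functional assay on A549 cells (Homo sapiens) for antiproliferative activity, read by MTT assay, with a stated time of 48 h (a higher number here means a weaker inhibitor, a lower number a stronger inhibitor), compound 1 (`C=C(c1ccc2c(c1)C=CC(C)(C)O2)c1ccc(OC)cc1NC(=O)CO`) gives 40 nM, compound 2 (`C=C(c1ccc(OC)cc1NC(=O)CN(C)C)c1ccc(OC)c2c1OC(C)(C)C=C2`) gives 270 nM and compound 3 (`C=C(c1cc(OC)c(OC)c(OC)c1)c1ccc(OC)c(O)c1NC(C)=O`) gives 80 nM. Compound 3 thus lies within the scatter of compound 1, while its number is lower than that of compound 2 by more than the scatter. Compound 4 (`C=C(c1cc(OC)c(OC)c(OC)c1)c1ccc(OC)c(O)c1NC(=O)CN(C)C`) carries dimethylamino in place of hydrogen on a saturated chain carbon bound to a carbonyl carbon. Within the data shown here, no measured pair isolates this change. Compound 2, at 270 nM, also carries dimethylamino on such a chain, though on a different core, so a modest weakening is expected in this assay. The estimated step of a 1.9-fold higher number from compound 3 to compound 4 (0.27 log units; within the scatter) may not clear the scatter. For compound 4 the estimated value is 150 nM, with an expected range from 50 nM to 450 nM.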

Compound 4, half-maximal inhibitory concentration: 50 nM
For compound 4 the middle estimate is 3.0-fold (0.48 log units) above the measured one, and the stated range covers the measured number.
By their numbers in this assay, from the lowest: compounds 1, 4 and 3 (each within the scatter of the next); then compound 2.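

On the shared core of compound 3 and compound 4, dimethylamino in place of hydrogen on a saturated chain carbon bound to a carbonyl carbon gives, in this assay, a 1.6-fold lower number from compound 3 to compound 4 (0.20 log units; within the scatter). Among these compounds, this is the first direct reading of the change, which compound 2, on a different core, could not give: the 3 heavy atoms entering here leave the two compounds within the scatter. Nothing available accounts for this result.

Still open, as far as these compounds go, is whether a primary amine, a carboxylic acid or a longer chain at this position would also stay within the scatter of compound 3.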